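Urea terminus variation in an indoleamine 2,3-dioxygenase 1 series

The compounds below may be only part of what the source reports. "The series", "measured", "known", "first", "only" and "open" are said of these compounds alone.

Compound 1 `CCCNC(=O)Nc1cc(/C(=N/O)Nc2ccc(F)c(Br)c2)ccc1N(CC(C)C)CC(C)C`: 2900 nM
Compound 2 `Cc1ccc(NC(=O)Nc2cc(/C(=N/O)Nc3ccc(F)c(Br)c3)ccc2N(CC(C)C)CC(C)C)cc1`: 2300 nM

Of the compounds shown here, two have been measured in an assay on isolated protein for inhibition of Indoleamine 2,3-dioxygenase 1 (Homo sapiens); a higher number here means a weaker inhibitor, a lower number a stronger inhibitor. Compound 1 gives 2900 nM, and compound 2 gives 2300 nM; the step of a 1.3-fold lower number from compound 1 to compound 2 (0.10 log units; within the scatter) lies within the scatter, so neither compound can be called the stronger inhibitor on these numbers. Among the measured compounds shown here, compound 2 holds the lowest of the two numbers, with compound 1 as its only neighbour.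

Compound 3 `CC(C)CN(CC(C)C)c1ccc(/C(=N/O)Nc2ccc(F)c(Br)c2)cc1NC(=O)Nc1ccc(C(F)(F)F)cc1` differs from compound 2 by trifluoromethyl in place of methyl on an aromatic carbon, the change sitting on an aromatic carbon of a six-membered aromatic ring of carbon only, para to a large group. For the measured compounds named here, no measured step addresses a trifluoromethyl in place of a methyl here; the one step available, a 1.3-fold lower number from compound 1 to compound 2 (0.10 log units; within the scatter), shows only that the amide-type nitrogen tolerates a very different substituent without a change beyond the scatter. Compound 3 is therefore expected to remain close to compound 2, with an estimated step of a 1.3-fold lower number from compound 2 to compound 3 (0.11 log units; within the scatter). Compound 3 is estimated at 1800 nM, with a range from 800 nM to 4000 nM.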

Compound 3, half-maximal inhibitory concentration: > 3000 nM
Compound 3: only a limit was reported; the forecaster's own chance of this, stated with the estimate: 2%; middle value at least 1.6-fold (0.22 log units) from the limit.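

In this assay compound 3 returned only a limit of the assay, > 3000 nM, and not a number. Going by these compounds, the two steps are therefore floors, an at least 1.3-fold higher number from compound 2 to compound 3 (0.11 log units; that floor lies within the scatter) and an at least 1.0-fold higher number from compound 1 to compound 3 (0.01 log units; that floor lies within the scatter), and neither shows a difference beyond the scatter, so how far the true value of compound 3 lies past the floor stays unknown: the limit of > 3000 nM in this assay, at which 1 of the 3 values shown sits. Where the earlier compounds spoke only to the substituent on the amide-type nitrogen, this result adds that trifluoromethyl in place of methyl on the aromatic carbon, para to a large group, gives no sign of a lower number in this series.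

On these data alone, how a chlorine, a methoxy group or a carboxylic acid on this same aromatic carbon would read remains open. So does whether a longer chain in place of propyl on the amide-type nitrogen would move the number beyond the scatter.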